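Swapping thiophen-2-yl for 4-methoxyphenyl on compound 2

The source may hold more compounds than are shown below. What is called first, only, known or untested is meant among the compounds shown, and "the series" means these compounds.

Measured so far in a functional assay on THP-1 cells (Homo sapiens) for inhibition, read by sulforhodamine B assay, with a stated time of 48 h, tested at 50 uM; a higher number here means more inhibition of growth at the concentration tested, a lower number less inhibition of growth (values in order):

Compound 1 (`COc1cccc(/C=C/C(=O)/C=C/c2ccc(OCc3cn(CCCCOc4cc(=O)oc5ccccc45)nn3)c(OC)c2)c1`): (47%)
Compound 2 (`COc1cc(/C=C/C(=O)/C=C/c2cccs2)ccc1OCc1cn(CCCCOc2cc(=O)oc3ccccc23)nn1`): (44%)

For the measured compounds named here, only these two numbers exist so far, and compound 2 cannot be told apart from compound 1, the only neighbour it has on the scale. The next compound to be read is compound 3 (`COc1ccc(/C=C/C(=O)/C=C/c2ccc(OCc3cn(CCCCOc4cc(=O)oc5ccccc45)nn3)c(OC)c2)cc1`). It differs from compound 2 as follows: 4-methoxyphenyl in place of thiophen-2-yl on a double-bonded chain carbon bound to a double-bonded chain carbon. In words, 4-methoxyphenyl stands in place of thiophen-2-yl on a double-bonded chain carbon bound to a double-bonded chain carbon.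

Going by the values given here, one measured step touches this same place, where thiophen-2-yl replaced 3-methoxyphenyl. That step reads a number 3 percentage points lower from compound 1 to compound 2 (within the scatter). Among the compounds with values here, it is small, and no measurement yet shows a compound carrying 4-methoxyphenyl. On these data alone, on that single step, no change beyond the scatter is expected in this assay, and the direction stays open. The estimated step is a number 2 percentage points higher from compound 2 to compound 3 (within the scatter). The value expected for compound 3 is 46%, with an estimated range from 33% to 58%.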

Compound 3, percent growth inhibition at one concentration: 45%
Compound 3: middle estimate off by 1 percentage points, on the high side; measured number inside the range.
By their numbers in this assay, from the lowest: compounds 2, 3 and 1 (each within the scatter of the next).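

In this assay, 4-methoxyphenyl in place of thiophen-2-yl gives a number 1 percentage points higher from compound 2 to compound 3 (within the scatter) and 4-methoxyphenyl in place of 3-methoxyphenyl gives a number 2 percentage points lower from compound 1 to compound 3 (within the scatter) at the same place, on a double-bonded chain carbon bound to a double-bonded chain carbon. Compound 3 is the first compound shown with 4-methoxyphenyl, and with it thiophen-2-yl, 3-methoxyphenyl and 4-methoxyphenyl cannot be told apart in this assay, so neither the swap of the five-membered aromatic ring for a six-membered one nor the different methoxyphenyl name shows up in the number. Nothing at hand explains why these compounds read alike.

The compounds shown leave open whether a dimethylamino group or a carboxylic acid on the aromatic ring at this place would give a step beyond the scatter. They also leave open whether a change elsewhere in the shared core, such as a longer chain, would move the number, as all the steps shown lie at this one place.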